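The source may report more compounds than this note shows. Statements on the series, on what has been measured and on what is new or still open speak of the compounds shown alone.

Of the compounds shown here, three sharing one core have been tested in an assay on isolated protein for inhibition of tyrosine-protein kinase receptor UFO (Homo sapiens), with a stated time of 1.5 h; on this read-out higher numbers stand for weaker inhibition and lower numbers for stronger inhibition. Compound 1 `Cn1cc(-c2n[nH]c3ccc(Br)cc23)cn1` carries a bromine on the core, and in this assay compound 1 gives 1540 nM. Compound 2 `Cn1cc(-c2n[nH]c3cc(-c4ccccc4)ccc23)cn1` carries a phenyl group instead, and in this assay compound 2 gives 12300 nM. Compound 3 `Cn1cc(-c2nn(C)c3cc(N)ccc23)cn1` carries an amino group and a methyl on an aromatic nitrogen of the core. In this assay compound 3 gives > 384000 nM, which is a limit of the assay rather than a number (the limit of > 384000 nM in this assay, at which 1 of the 3 values shown sits). Compound 3 is thus the only one of the three for which no number is known.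

Compound 4 `Cn1cc(-c2n[nH]c3cc(N)ccc23)cn1` has not yet been measured. It differs from compound 3 in one place: hydrogen in place of methyl on an aromatic nitrogen. Compound 1, with hydrogen on this aromatic nitrogen, gives 1540 nM in this assay, and compound 2, also with hydrogen there, gives 12300 nM. Compound 3, with the methyl, gives only a limit. On that basis the step is expected to be large toward stronger inhibition, an at least 19-fold lower number from compound 3 to compound 4 (1.28 log units; beyond the scatter). Compound 4 is therefore expected to reach about 20000 nM in this assay, within a range from 3000 nM to 150000 nM.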

Compound 4, half-maximal inhibitory concentration: 28800 nM
Compound 4: middle estimate off by 1.4-fold (0.16 log units), on the low side; the range from low to high includes it.
By their numbers in this assay, from the lowest: compound 1; then compound 2; then compound 4. At a limit, above all of these: compound 3.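

Within the data shown here, with an amino group on the core, hydrogen in place of methyl on an aromatic nitrogen gives an at least 13-fold lower number from compound 3 to compound 4 (1.12 log units; beyond the scatter) in this assay, and this is the first pair here that differs at this nitrogen alone. Going by these compounds, compound 3 stands at a limit of the assay and not at a number, so the full size of this step stays unknown: the limit of > 384000 nM in this assay, at which 1 of the 4 values shown sits. Amino in place of phenyl on an aromatic carbon gives a 2.3-fold higher number from compound 2 to compound 4 (0.37 log units; beyond the scatter), a smaller shift than the one at the nitrogen.

On these data alone, whether the step at the nitrogen has a similar size with phenyl or bromine on the core stays open. Also open, as far as these compounds go, is how the number would move with an ethyl group on that nitrogen, or with a methoxy group or a carboxylic acid in place of the amino group.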